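The source may report more compounds than this note shows. Statements on the series, on what has been measured and on what is new or still open speak of the compounds shown alone.

Compound 1 (`CCC(CC)(c1ccc(OCC(O)C(C)(C)C)c(C)c1)c1ccc(C(=O)N[C@@H](C)CO)n1C`) gives the highest number of the three in a functional assay on HaCaT cells (Homo sapiens) for cytotoxicity, read by MTT assay, with a stated time of 48 h (on this read-out higher numbers stand for weaker inhibition and lower numbers for stronger inhibition), at 15700 nM against compound 2 (`CCn1c(C(=O)N[C@@H](C)CO)ccc1C(CC)(CC)c1ccc(OCC(O)C(C)(C)C)c(C)c1`) at 2060 nM and compound 3 (`CCn1c(C(=O)N[C@H](CO)CCO)ccc1C(CC)(CC)c1ccc(OCC(O)C(C)(C)C)c(C)c1`) at 1250 nM on the same read-out. Compound 4 (`CCC(CC)(c1ccc(OCC(O)C(C)(C)C)c(C)c1)c1ccc(C(=O)NCC(=O)O)n1C`) carries carboxymethyl in place of 1-(hydroxymethyl)ethyl on the amide-type nitrogen (carboxymethyl in place of 1-(hydroxymethyl)ethyl on an amide-type nitrogen). Going by the values given here, the one measured change in that amide side chain (a 1.6-fold lower number from compound 2 to compound 3 (0.22 log units; within the scatter)) stays within the scatter. The larger step (a 7.6-fold lower number from compound 1 to compound 2 (0.88 log units; beyond the scatter)) sits on the aromatic nitrogen and bears only weakly. Among the compounds with values here, no measured compound carries carboxymethyl, so the expectation is loose: no step beyond the scatter in this assay is expected. This estimate means an expected 1.3-fold higher number from compound 1 to compound 4 (0.11 log units; within the scatter) in this series. Compound 4 is expected at 20000 nM (estimated range 7000 nM to 60000 nM).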

Compound 4, half-maximal inhibitory concentration: 9810 nM
Compound 4: the middle estimate sits 2.0-fold (0.31 log units) above what was measured; low and high end bracket the measured number.
By their numbers in this assay, from the lowest: compounds 3 and 2 (each within the scatter of the next); then compounds 4 and 1 (each within the scatter of the next).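

On the amide-type nitrogen, carboxymethyl in place of 1-(hydroxymethyl)ethyl gives a 1.6-fold lower number from compound 1 to compound 4 (0.20 log units; within the scatter) in this assay, a swap of the whole side chain that also removes the defined stereocentre. Earlier, this side chain had only gained a hydroxymethyl, with a 1.6-fold lower number from compound 2 to compound 3 (0.22 log units; within the scatter), so the read-out now stays within the scatter across a change in the group itself. No evidence is available to explain this result.

Still open, from the compounds shown here alone, is whether an aminoethyl group or the methyl ester of carboxymethyl on this nitrogen stays within the scatter. Also open, going by these compounds, is whether carboxymethyl gives the same result with ethyl on the aromatic nitrogen, as in compound 2.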